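The source may report more compounds than this note shows. Statements on the series, on what has been measured and on what is new or still open speak of the compounds shown alone.

Measured so far in a functional assay on A549 cells (Homo sapiens) for antiproliferative activity, read by MTT assay, with a stated time of 24 h (a higher number here means a weaker inhibitor, a lower number a stronger inhibitor), for two compounds:
compound 1 `Cc1ccc(-c2nn(-c3ccccc3)cc2-c2nc3ccccc3[nH]2)cc1` gives 4010 nM
compound 2 `Cc1ccc(-c2nn(-c3ccccc3)cc2-c2nc3ccccc3n2S(=O)(=O)c2ccc(C)cc2)cc1` gives 460 nM

Compound 2, at 460 nM here, holds the lower of the two numbers. Next comes compound 3 `Cc1ccc(-c2nn(-c3ccccc3)cc2-c2nc3ccccc3n2S(=O)(=O)c2ccc(Br)cc2)cc1` with the change bromo in place of methyl on an aromatic carbon in the form of bromo in place of methyl on an aromatic carbon, para to a large group. Going by the values given here, only one measured step bears on this group: an 8.7-fold lower number from compound 1 to compound 2 (0.94 log units; beyond the scatter) for (4-methylphenyl)sulfonyl in place of hydrogen on an aromatic nitrogen. That step adds the whole group and does not vary its methyl, so the data hold no direct measure of this change. No step beyond the scatter is expected and no direction is favoured, so the estimate is a 1.1-fold lower number from compound 2 to compound 3 (0.03 log units; within the scatter) for this change. For compound 3 the expected value is 430 nM with an estimated range from 170 nM to 1100 nM in this assay.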

Compound 3, half-maximal inhibitory concentration: 1860 nM
Estimate against measurement, compound 3: 4.3-fold (0.64 log units) below, and the stated range ends below it.
By their numbers in this assay, from the lowest: compound 2; then compound 3; then compound 1.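

In this assay, the group at this place on the sulfonyl-bound aromatic ring matters: a 4.0-fold higher number from compound 2 to compound 3 (0.61 log units; beyond the scatter) for bromo in place of methyl, so the earlier gain cannot be credited to the sulfonyl unit alone. The (4-bromophenyl)sulfonyl group still keeps part of that gain, with a 2.2-fold lower number from compound 1 to compound 3 (0.33 log units; beyond the scatter), a smaller step than an 8.7-fold lower number from compound 1 to compound 2 (0.94 log units; beyond the scatter). No measurement at hand accounts for the difference between methyl and bromo.

As far as these compounds go, with only these two groups at this place, no trend can be drawn, and the standing of a methoxy, an amine or a carboxylic acid there remains open. Also open, from the compounds shown here alone, is how the unsubstituted phenylsulfonyl group, with hydrogen at this place, would compare with compound 2 and compound 3.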